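The compounds below may be only part of what the source reports. "The series", "measured", "known", "first", "only" and "open" are said of these compounds alone.

Compound 1 `N#Cc1ccccc1-c1cc(F)cc(-n2nnc(-c3ccccn3)n2)c1` gives 6 nM in a functional assay for antagonist activity at metabotropic glutamate receptor 5 (Rattus norvegicus); on this read-out higher numbers stand for weaker inhibition and lower numbers for stronger inhibition; compound 2 `Fc1cc(-c2ccccn2)cc(-n2nnc(-c3ccccn3)n2)c1` gives 39 nM; compound 3 `Cc1ccncc1-c1cc(F)cc(-n2nnc(-c3ccccn3)n2)c1` gives 5 nM.

Compound 3 has the lowest of the three numbers, but its gap to compound 1 lies within the scatter (a 1.2-fold lower number from compound 1 to compound 3 (0.08 log units; within the scatter)), and only compound 2 stands clearly apart (a 7.8-fold lower number from compound 2 to compound 3 (0.89 log units; beyond the scatter)). Compound 4 `Nc1ccncc1-c1cc(F)cc(-n2nnc(-c3ccccn3)n2)c1` differs from compound 3 by amino in place of methyl on an aromatic carbon. Among the compounds with values here, no measured step changes a single substituent on this ring; the steps seen, a 6.5-fold higher number from compound 1 to compound 2 (0.81 log units; beyond the scatter) and a 7.8-fold lower number from compound 2 to compound 3 (0.89 log units; beyond the scatter), swap whole aryl groups, and they show that alterations at this part of the molecule can move the number beyond the scatter. For compound 4 a step of uncertain direction is therefore expected, leaning towards a somewhat higher number: a 3.0-fold higher number from compound 3 to compound 4 (0.48 log units; beyond the scatter). Compound 4 is estimated at 15 nM, between 4 nM and 60 nM.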

Compound 4, half-maximal inhibitory concentration: 108 nM
For compound 4 the middle estimate is 7.2-fold (0.86 log units) below the measured one; measured number above the stated range.
By their numbers in this assay, from the lowest: compounds 3 and 1 (each within the scatter of the next); then compound 2; then compound 4.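

In this assay amino in place of methyl gives a 22-fold higher number from compound 3 to compound 4 (1.33 log units; beyond the scatter) and so shows that a swap of one heavy atom on this ring, not only a swap of a whole aryl group, can move the number far beyond the scatter. The 4-aminopyridin-3-yl group also ends up with the highest number of the set, with a 2.8-fold higher number from compound 2 to compound 4 (0.44 log units; beyond the scatter) and an 18-fold higher number from compound 1 to compound 4 (1.26 log units; beyond the scatter) as its steps from the two other aryl groups. As far as these compounds go, whether a hydroxyl or a methoxy group at this place would behave like methyl or like amino remains open. No measurement shown here explains the rise in the number.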